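Swapping a Cyanophenyl Arm for Trimethoxyphenyl on a Cytotoxic Core

The compounds below may be only part of what the source reports. "The series", "measured", "known", "first", "only" and "open" are said of these compounds alone.

Compound 1 `N#Cc1ccc(/C=C2\CN(S(=O)(=O)c3ccc(F)cc3)C/C(=C\c3ccccc3F)C2=O)cc1`: in a functional assay on SMMC-7721 cells (Homo sapiens) for cytotoxicity, read by MTT assay, with a stated time of 24 h (on this read-out lower numbers stand for stronger inhibition and higher numbers for weaker inhibition), compound 1 gives 10300 nM.
Compound 2 `COc1cc(/C=C2\CN(S(=O)(=O)c3ccc(F)cc3)C/C(=C\c3ccccc3F)C2=O)cc(OC)c1OC`: in this assay compound 2 gives 6340 nM.
Compound 3 `CC(=O)Nc1ccc(S(=O)(=O)N2C/C(=C\c3ccc(C#N)cc3)C(=O)/C(=C/c3ccccc3F)C2)cc1`: in this assay compound 3 gives 3150 nM.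

Compound 2 carries 3,4,5-trimethoxyphenyl in place of 4-cyanophenyl on a double-bonded chain carbon bound to a double-bonded ring carbon, and this gave a 1.6-fold lower number from compound 1 to compound 2 (0.21 log units; within the scatter). Compound 3 differs from compound 1 in its core by acetamido in place of fluoro on an aromatic carbon, which gave a 3.3-fold lower number from compound 1 to compound 3 (0.51 log units; beyond the scatter). Compound 4 `COc1cc(/C=C2\CN(S(=O)(=O)c3ccc(NC(C)=O)cc3)C/C(=C\c3ccccc3F)C2=O)cc(OC)c1OC`, not yet measured, differs from compound 3 by 3,4,5-trimethoxyphenyl in place of 4-cyanophenyl on a double-bonded chain carbon bound to a double-bonded ring carbon; the place of the change matches that between compound 1 and compound 2 word for word, so it is the same change made on the core of compound 3. Among the compounds with values here, the step from compound 3 to compound 4 is expected to be a 1.6-fold lower number from compound 3 to compound 4 (0.20 log units; within the scatter) in this assay, resting on compound 1 and compound 2 because a 1.6-fold lower number from compound 1 to compound 2 (0.21 log units; within the scatter) is the only measured instance of this change. Compound 4 is therefore estimated at 2000 nM, expected to fall between 900 nM and 4500 nM.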

Compound 4, half-maximal inhibitory concentration: 3920 nM
Compound 4: middle estimate off by 2.0-fold (0.29 log units), on the low side, within the range that was stated.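

Putting 3,4,5-trimethoxyphenyl in place of 4-cyanophenyl gave a 1.2-fold higher number from compound 3 to compound 4 (0.09 log units; within the scatter) in this assay, a step that agrees with its earlier instance: the same change on two cores in this assay, a 1.6-fold lower number (0.21 log units; within the scatter) from compound 1 to compound 2 and a 1.2-fold higher number (0.09 log units; within the scatter) from compound 3 to compound 4, 2.0-fold (0.31 log units) apart, within the scatter of two such steps. Acetamido in place of fluoro gave a 1.6-fold lower number from compound 2 to compound 4 (0.21 log units; within the scatter), which also agrees with its earlier instance, although only that earlier step lies beyond the scatter: the same change on two cores in this assay, a 3.3-fold lower number (0.51 log units; beyond the scatter) from compound 1 to compound 3 and a 1.6-fold lower number (0.21 log units; within the scatter) from compound 2 to compound 4, 2.0-fold (0.31 log units) apart, within the scatter of two such steps. Within the data shown here, with only two cores and steps this small, the results show no detectable disagreement between cores, but they do not establish a dependable size or direction for either change on another core.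

The compounds shown leave open what an amine or a carboxylic acid would do in place of acetamido on that aromatic carbon. They also leave open whether either change would hold on other cores.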